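This account rests on a few compounds, and the source may have more. Where it says the series, first, only, none or still open, it means among the compounds named here.

Measured compounds:
compound 1 `CN1[C@@H]2c3[nH]c4ccccc4c3C[C@H]1[C@H](C#N)N1[C@@H](CNC(=O)c3ccc4ccccc4c3)c3[nH]c4ccccc4c3C[C@@H]21` gives 1210 nM in a functional assay on HepG2 cells (Homo sapiens) for cytotoxicity, read by MTT assay, with a stated time of 72 h; a lower number here means a stronger inhibitor, a higher number a weaker inhibitor
compound 2 `CN1[C@@H]2c3[nH]c4ccccc4c3C[C@H]1[C@H](C#N)N1[C@@H](CNC(=O)c3ccc4ccccc4n3)c3[nH]c4ccccc4c3C[C@@H]21` gives 110 nM in this assay

Compound 1 stands with the highest of the two numbers; its nearest neighbour is compound 2, and the step of an 11-fold lower number from compound 1 to compound 2 (1.04 log units; beyond the scatter) lies beyond the scatter. Compound 3 `COc1ccc(/C=C/C(=O)NC[C@H]2c3[nH]c4ccccc4c3C[C@H]3[C@H]4c5[nH]c6ccccc6c5C[C@@H]([C@H](C#N)N23)N4C)cc1` differs from compound 1 by 2-(4-methoxyphenyl)ethenyl in place of naphthalen-2-yl on a carbonyl carbon. Among the compounds with values here, no measured step covers this change. Within the data shown here, the only measured step alters the same carbonyl carbon with quinolin-2-yl, which shows that this position shifts the number without indicating the direction for the new group. For compound 3 the expected step is a 1.5-fold lower number from compound 1 to compound 3 (0.18 log units; within the scatter). Compound 3 is estimated at 800 nM, with a range of 200 nM to 3000 nM.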

Compound 3, half-maximal inhibitory concentration: 2140 nM
Estimate against measurement, compound 3: 2.7-fold (0.43 log units) below; measured number inside the range.
By their numbers in this assay, from the lowest: compound 2; then compounds 1 and 3 (each within the scatter of the next).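

In this assay, 2-(4-methoxyphenyl)ethenyl in place of naphthalen-2-yl on the carbonyl carbon gives a 1.8-fold higher number from compound 1 to compound 3 (0.25 log units; within the scatter), so one aromatic ring with a double bond serves no differently here from two aromatic rings of carbon only. Quinolin-2-yl alone stands apart among the three groups, with a 19-fold higher number from compound 2 to compound 3 (1.29 log units; beyond the scatter). No evidence is available to explain this difference.

Going by these compounds, whether a smaller pyridin-2-yl group on the same carbonyl carbon would keep the low number of compound 2 remains open. So does the effect of removing the methoxy group from the 2-(4-methoxyphenyl)ethenyl group.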